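The source may hold more compounds than are shown below. What is called first, only, known or untested is meant among the compounds shown, and "the series" means these compounds.

Series notes. The shared core is seen in compound 1 `COc1ccc(OCC2=NCCO2)cc1`. In a functional assay on the whole organism for inhibition, with Rattus norvegicus as the target, read by paw edema, with a stated time of 30 min, at a dose of 20 mg/kg by the oral route (a higher number here means a stronger effect of the compound at the dose given, a lower number a weaker effect), compound 1 gives 16.6%. Compound 2 `Brc1ccccc1OCC1=NCCO1` gives 20.1% in this assay, and compound 3 `Clc1ccccc1OCC1=NCCO1` gives 13.7%. Compound 1 thus stands second of the three numbers, but its gap to compound 3 and its gap to compound 2 are both within the scatter, so none of the three can be set above the others.

Compound 4 `Fc1ccc(OCC2=NCCO2)cc1` is not yet measured. It differs from compound 1 by fluoro in place of methoxy on an aromatic carbon. Going by the values given here, the only single-point step measured so far, a number 6.4 percentage points lower from compound 2 to compound 3 (within the scatter), concerns chloro in place of bromo and lies within the scatter; no measured step puts a halogen in place of methoxy, so the present change has no direct precedent. Nothing measured points to a shift beyond the scatter in either direction. A value near that of compound 1 is therefore expected for compound 4, namely 15%, with a range from 5% to 25%. The expected step is accordingly a number 1.6 percentage points lower from compound 1 to compound 4 (within the scatter), within the scatter.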

Compound 4, a percentage reported as inhibition, in the whole organism at one dose (the size of the read-out at that dose, not a potency): 18.5%
For compound 4 the middle estimate is 3.5 percentage points below the measured one; low and high end bracket the measured number.
By their numbers in this assay, from the lowest: compounds 3, 1, 4 and 2 (each within the scatter of the next).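

At this place, on an aromatic carbon para to a group of 7 heavy atoms, the series now has its first step that puts a halogen in place of methoxy: in this assay the step is a number 1.9 percentage points higher from compound 1 to compound 4 (within the scatter). The exchange takes out the hydrogen-bond acceptor counted for methoxy and a heavy atom, and the read-out at this single dose cannot separate the two compounds. No measurement shown bears on why, so no cause can be given.

Every step shown lies within the scatter, so it remains open whether any group at this place can give a step beyond it. An amine, a carboxylic acid or a longer alkoxy chain at this place would test that.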